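A few compounds are considered here, and "the series" means these few. Any claim that something is new, unique, unknown or untested is made for them only; others in the source may bear on it.

Working notes on the series. In an assay for inhibition of 15-hydroxyprostaglandin dehydrogenase [NAD(+)] (Homo sapiens), read by fluorescence, with a stated time of 15 min, in the presence of a further agent that is not named here (a higher number here means a weaker inhibitor, a lower number a stronger inhibitor), compound 1 `CCCC[S+]([O-])c1nc2ccc(-c3cccs3)nc2s1` gives 1230 nM, compound 2 `CCCCCC[S+]([O-])c1sc2nc(-c3cccs3)cc(-c3ccccc3)c2c1N` gives 18 nM, and compound 3 `CCCC[S+]([O-])c1sc2nc(-c3nccs3)cc(-c3ccc(CCO)cc3)c2c1N` gives 2.9 nM. Compound 2 stands second highest of the three numbers: compound 3 sits nearest, with a lower number beyond the scatter, and compound 1 sits furthest, with a far higher number.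

Compound 4 `CCCCC(=O)c1sc2nc(-c3cccs3)cc(-c3ccccc3)c2c1N` has not yet been measured in this assay. It differs from compound 2 as follows: a group of 6 heavy atoms (5 carbon, 1 oxygen; no ring) in place of a group of 8 heavy atoms (6 carbon, 1 oxygen, 1 sulfur; no ring), on an aromatic carbon. Among the measured compounds shown here, no step between measured compounds covers this kind of change, so there is nothing to anchor its size; the expectation is a modest step toward a higher number from compound 2 to compound 4, a 2.5-fold higher number from compound 2 to compound 4 (0.40 log units; beyond the scatter), which may still fall within the scatter. Compound 4 is therefore expected to give about 45 nM in this assay, within the range 10 nM to 250 nM.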

Compound 4, half-maximal inhibitory concentration: > 7500 nM
Compound 4 was reported as a limit (the forecaster's own chance of this, stated with the estimate: 5%); middle value at least 160-fold (2.22 log units) from the limit.
By their numbers in this assay, from the lowest: compound 3; then compound 2; then compound 1. At a limit, above all of these: compound 4.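

Compound 4 is reported only as a limit, not as a number: the limit of > 7500 nM in this assay, at which 1 of the 4 values shown sits.

In this assay, butylcarbonyl in place of the group of 8 heavy atoms, on the aromatic carbon next to the ring sulfur, gives an at least 410-fold higher number from compound 2 to compound 4 (2.61 log units; beyond the scatter). Among the compounds shown here, compounds 1, 2 and 3 all keep a sulfur-oxygen group here, so only this step shows how strongly the value depends on the group at this position.

From the compounds shown here alone, it remains open whether the carbonyl or the shorter chain accounts for the step. A longer chain on the carbonyl, or an amide here, would separate the two.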